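The compounds below may be only part of what the source reports. "The series", "measured", "known", "first", "only" and "open" are said of these compounds alone.

In a functional assay on MDA-MB-231 cells (Homo sapiens) for inhibition, read by MTT assay, with a stated time of 72 h (on this read-out higher numbers stand for weaker inhibition and lower numbers for stronger inhibition), three compounds built on one shared core have been measured so far. Compound 1 `CC(C)(C)n1cc2c(n1)C(=O)CC1(CCN(C(=O)c3cc(-c4ccccc4)nc4ccccc34)CC1)O2` gives > 10000 nM, which is a limit and not a number. Compound 2 `Cc1ccccc1-c1cc(C(=O)N2CCC3(CC2)CC(=O)c2nn(C(C)(C)C)cc2O3)c2ccccc2n1` gives > 10000 nM, again only a limit. Compound 3 `CC(C)(C)n1cc2c(n1)C(=O)CC1(CCN(C(=O)c3cc(-c4ccc(Cl)cc4)nc4ccccc34)CC1)O2` gives > 10000 nM, also only a limit, so it has no exact place on the scale.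

Compound 4 `CC(C)(C)n1cc2c(n1)C(=O)CC1(CCN(C(=O)c3cc(-c4ccccc4Cl)nc4ccccc34)CC1)O2` has the same atoms as compound 3, joined differently: 2-chlorophenyl in place of 4-chlorophenyl, on an aromatic carbon next to the ring nitrogen (2-chlorophenyl in place of 4-chlorophenyl on an aromatic carbon).

The closest evidence comes from changes on this same aromatic group: a step that the two limits leave unreadable from compound 1 to compound 2, a step that the two limits leave unreadable from compound 1 to compound 3 and a step that the two limits leave unreadable from compound 2 to compound 3. None of these has a size that can be carried over, and the whole set stands at the limit of > 10000 nM in this assay, at which 3 of the 3 values shown sit. No step beyond the scatter is therefore expected, in either direction. The estimated change is a step that the limit leaves unreadable from compound 3 to compound 4. Compound 4 is expected at 12000 nM, with an estimated range from 5000 nM to 30000 nM, and it will most likely be reported only as a limit.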

Compound 4, half-maximal inhibitory concentration: > 10000 nM
Compound 4: a limit, no number; the forecaster's own chance of this, stated with the estimate: 85%; the middle value does not contradict the limit.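

Among the compounds shown here, compound 4 is reported only as a limit, as are compound 1, compound 2 and compound 3, so no step among them can be read: the limit of > 10000 nM in this assay, at which 4 of the 4 values shown sit. Going by these compounds, how strongly these compounds inhibit in this assay, and whether 2-chlorophenyl and 4-chlorophenyl differ at all, stays open.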